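This account rests on a few compounds, and the source may have more. Where it says the series, first, only, none or still open, it means among the compounds named here.

Series notes. Compound 1 `COc1ccc(S(=O)(=O)N2CCc3cccc(-c4cccnc4)c32)cc1`, compound 2 `COc1ccc(S(=O)(=O)N2CCc3cccc(-c4ccc(F)nc4)c32)cc1`, compound 3 `COc1ccc(S(=O)(=O)N2CCc3cccc(-c4c(F)c(F)c(F)c(F)c4F)c32)cc1` and the unmeasured compound 4 `COc1ccc(S(=O)(=O)N2CCc3cccc(-c4cccc(F)c4)c32)cc1` share one core and differ only in the aromatic group on the aromatic carbon ortho to a fused ring. In a functional assay on KB-VIN10 cells (Homo sapiens) for inhibition, with a stated time of 72 h (a higher number here means a weaker inhibitor, a lower number a stronger inhibitor), compound 1 gives 84.5 nM, compound 2 gives 151 nM and compound 3 gives 4630 nM. Compound 2 therefore holds the second highest of the three numbers, nearest to compound 1 and with compound 3 furthest away. Among the compounds with values here, the only measured step, a 1.8-fold higher number from compound 1 to compound 2 (0.25 log units; within the scatter), bears only loosely on the present change, which is 3-fluorophenyl in place of 6-fluoropyridin-3-yl on an aromatic carbon. Within the data shown here, no measured pair exchanges the ring nitrogen for carbon, so in this assay no shift beyond the scatter is expected from compound 2 to compound 4. Compound 4 is thus estimated at 150 nM with a range from 60 nM to 400 nM, an expected step of a 1.0-fold lower number from compound 2 to compound 4 (0.00 log units; within the scatter).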

Compound 4, half-maximal inhibitory concentration: 92.4 nM
The estimate for compound 4 lay 1.6-fold (0.21 log units) above the measured number; the range from low to high includes it.
By their numbers in this assay, from the lowest: compounds 1, 4 and 2 (each within the scatter of the next); then compound 3.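

In this assay, 3-fluorophenyl in place of 6-fluoropyridin-3-yl gives a 1.6-fold lower number from compound 2 to compound 4 (0.21 log units; within the scatter), and 3-fluorophenyl in place of pyridin-3-yl gives a 1.1-fold higher number from compound 1 to compound 4 (0.04 log units; within the scatter). An aromatic ring of carbon only thus serves at this position without a shift beyond the scatter, so the ring nitrogen is not required to hold this level in either comparison. No evidence on the reason for this is at hand.

Open, from the compounds shown here alone, is whether unsubstituted phenyl, or a ring carrying an amine or a carboxylic acid, would hold the same level here.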